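From diethylamino to dipentylamino on the shared side chain

The compounds below may be only part of what the source reports. "The series", "measured", "known", "first", "only" and "open" are said of these compounds alone.

Of the compounds shown here, three sharing one core have been measured in a functional assay on PC-3 cells (Homo sapiens) for antiproliferative activity, read by WST assay, with a stated time of 3 days; on this read-out higher numbers stand for weaker inhibition and lower numbers for stronger inhibition. Compound 1 `CCOc1c(-c2cc(OC)c(OC)c(OC)c2)oc2ccccc2c1=O` gives 900 nM, compound 2 `CCCC(C)Oc1c(-c2cc(OC)c(OC)c(OC)c2)oc2ccccc2c1=O` gives 49300 nM, and compound 3 `CCN(CC)CCCCCOc1c(-c2cc(OC)c(OC)c(OC)c2)oc2ccccc2c1=O` gives 6600 nM, the middle number of the three. The next compound, compound 4 `CCCCCN(CCCCC)CCCCOc1c(-c2cc(OC)c(OC)c(OC)c2)oc2ccccc2c1=O`, departs from compound 3 as follows: dipentylamino in place of (diethylamino)methyl on a saturated chain carbon, four bonds along the chain from an oxygen on an aromatic ring. In words, it carries dipentylamino in place of (diethylamino)methyl on a saturated chain carbon, four bonds along the chain from an oxygen on an aromatic ring. The closest evidence is a 7.3-fold higher number from compound 1 to compound 3 (0.87 log units; beyond the scatter) and a 7.5-fold lower number from compound 2 to compound 3 (0.87 log units; beyond the scatter), both modest, while a 55-fold higher number from compound 1 to compound 2 (1.74 log units; beyond the scatter) was large. Within the data shown here, these steps show that the number moves with the side chain, but no measured pair varies the groups on the amine nitrogen. The data therefore give no firm direction, and at most a modest step is expected in this assay. The expected change is a 1.3-fold lower number from compound 3 to compound 4 (0.12 log units; within the scatter), which stays within the scatter. For compound 4 the estimated value is 5000 nM, with an expected range from 1500 nM to 20000 nM.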

Compound 4, half-maximal inhibitory concentration: 7900 nM
Compound 4: middle estimate off by 1.6-fold (0.20 log units), on the low side; the range from low to high includes it.
By their numbers in this assay, from the lowest: compound 1; then compounds 3 and 4 (each within the scatter of the next); then compound 2.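

In this assay the exchange at this place, on a saturated chain carbon, four bonds along the chain from an oxygen on an aromatic ring, gives a 1.2-fold higher number from compound 3 to compound 4 (0.08 log units; within the scatter) and so leaves the two compounds within the usual scatter. Among these compounds, this is the first pair here that varies the groups on the amine nitrogen, and it shows that dipentylamino, with 11 heavy atoms, is tolerated in place of (diethylamino)methyl, with 6. Nothing measured accounts for this outcome.

Among the compounds shown here, since the one step alters both the chain leading to the nitrogen and the groups on it, the two contributions remain unseparated. Also open, going by these compounds, is how a piperidine or morpholine ring on the nitrogen, or a primary amine at the end of the same chain, would compare.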